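Notes on the step from compound 2 to compound 3

The source may report more compounds than this note shows. Statements on the series, on what has been measured and on what is new or still open speak of the compounds shown alone.

In a functional assay on K562 cells (Homo sapiens) for antiproliferative activity, read by trypan blue exclusion, with a stated time of 48 h, tested at 10 uM (a higher number here means more inhibition of growth at the concentration tested, a lower number less inhibition of growth), compound 1 `NC(=O)c1cc(Cl)ccc1NC(=O)/C=C/c1ccccc1Br` gives 49%. Compound 2 `NC(=O)c1cc(Br)ccc1NC(=O)/C=C/c1cccc(Cl)c1` gives 25.5%, the lower of the two numbers, and the gap between them lies beyond the scatter. For the measured compounds named here, no measured pair differs in one place only, so the data offer no direct guide to a single change. Compound 3 `Cc1ccc(/C=C/C(=O)Nc2ccc(Br)cc2C(N)=O)cc1` follows from compound 2 through (4-methylphenyl in place of 3-chlorophenyl on a double-bonded chain carbon bound to a double-bonded chain carbon). Going by the values given here, with no measured precedent, a small upward move within the scatter is expected, and the estimated change is a number 4.5 percentage points higher from compound 2 to compound 3 (within the scatter). For compound 3 the expected value is 30%, with an estimated range of 12% to 50%.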

Compound 3, percent growth inhibition at one concentration: 45.9%
Beside the measured number, compound 3's estimate is 15.9 percentage points below it; measured number inside the range.
By their numbers in this assay, from the lowest: compound 2; then compounds 3 and 1 (each within the scatter of the next).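

In this assay, for the compounds shown here, 4-methylphenyl in place of 3-chlorophenyl on a double-bonded chain carbon bound to a double-bonded chain carbon gives a number 20.4 percentage points higher from compound 2 to compound 3 (beyond the scatter) as the only single-place step so far, which shows that the read-out responds to the group at this position. The two groups share a heavy-atom count and a six-membered aromatic ring of carbon only, yet they differ in both substituent and its place on the ring. No available evidence accounts for the rise.

Which of those two differences carries the step remains open. A 4-chlorophenyl or 3-methylphenyl group at this position would separate them, while a ring bearing an amine or a carboxylic acid would test a wider range of substituents.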